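Swapping Methyl for Chloro on the Phenyl Ring

The source may hold more compounds than are shown below. What is called first, only, known or untested is meant among the compounds shown, and "the series" means these compounds.

Compound 3 `COC(=O)c1c(-c2cc3ccccc3oc2=O)nn(-c2cccc(C)c2)c1C(=O)OC` gives 35000 nM in a functional assay on DU-145 cells (Homo sapiens) for cytotoxicity, read by MTT assay, with a stated time of 48 h; on this read-out lower numbers stand for stronger inhibition and higher numbers for weaker inhibition. Compound 1 `COC(=O)c1c(-c2cc3ccccc3oc2=O)nn(-c2ccccc2)c1C(=O)OC` gives 30000 nM, and compound 2 `CCOC(=O)c1c(-c2cc3ccccc3oc2=O)nn(-c2cccc(C)c2)c1C(=O)OCC` gives 47000 nM; all three numbers lie within the usual scatter of one another, so compound 3 stands among them without a clear separation. Among the measured compounds shown here, the one measured step, a 1.2-fold higher number from compound 1 to compound 3 (0.07 log units; within the scatter), shows that adding a methyl on an aromatic carbon left the number essentially unchanged. Compound 4 `COC(=O)c1c(-c2cc3ccccc3oc2=O)nn(-c2cccc(Cl)c2)c1C(=O)OC` differs from compound 3 by chloro in place of methyl on an aromatic carbon. For the measured compounds named here, no measured pair tests a chloro, so the methyl step is the only guide, and it suggests that a group at this place barely moves this assay. Compound 4 is therefore expected to stay within the scatter of compound 3, no change at the digits printed from compound 3 to compound 4 (within the scatter). The estimate for compound 4 is 35000 nM, with a range from 15000 nM to 80000 nM.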

Compound 4, half-maximal inhibitory concentration: 32000 nM
Beside the measured number, compound 4's estimate is 1.1-fold (0.04 log units) above it; measured number inside the range.
By their numbers in this assay, from the lowest: compounds 1, 4, 3 and 2 (each within the scatter of the next).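

Chloro now joins methyl at this aromatic carbon, and in this assay neither separates from hydrogen. Swapping the methyl for chloro gives (a 1.1-fold lower number from compound 3 to compound 4 (0.04 log units; within the scatter)), and chloro set against hydrogen gives (a 1.1-fold higher number from compound 1 to compound 4 (0.03 log units; within the scatter)), so in this set two different groups, not just one, leave the number within the scatter. Nothing available explains why this place tolerates these changes.

On these data alone, whether an amine or a carboxylic acid at this carbon would move the number stays open. So does whether chloro on another carbon of this ring would do so.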